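Alkoxy placement on the acid chain of the shared core

This account rests on a few compounds, and the source may have more. Where it says the series, first, only, none or still open, it means among the compounds named here.

Measured compounds:
compound 1 `Cc1cccc(C)c1-c1cccc(COc2ccc(CCC(=O)O)cn2)c1`: 38 nM
compound 2 `COC(Cc1ccc(OCc2cccc(-c3c(C)cccc3C)c2)nc1)C(=O)O`: > 10000 nM

In a functional assay on CHO cells for agonist activity at Free fatty acid receptor 1 (Rattus norvegicus), read by calcium flux (on this read-out higher numbers stand for an effect only at larger amounts of compound and lower numbers for an effect already at smaller amounts), compound 1 gives 38 nM. For compound 2 the read-out is only a limit, > 10000 nM, as recorded in the limit of > 10000 nM in this assay, at which 1 of the 2 values shown sits. Going by the values given here, the single measured step, an at least 260-fold higher number from compound 1 to compound 2 (2.42 log units; beyond the scatter), shows that placing a methoxy group on the saturated chain carbon bound to the carbonyl removes measurable agonism from the core of compound 1.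

Compound 3 `CCOC(CC(=O)O)c1ccc(OCc2cccc(-c3c(C)cccc3C)c2)nc1` is the next point on this chain. The change is 2-carboxy-1-ethoxyethyl in place of 2-carboxy-2-methoxyethyl on an aromatic carbon. Among the compounds with values here, no measured pair carries this exact change; the only bearing step is the one from compound 1 to compound 2, which is large and runs toward weaker agonism, so an alkoxy group on the acid chain is, on present numbers, a liability. Moving it to the other chain carbon and lengthening it to ethoxy has no precedent here, so compound 3 is expected to sit weak but with wide uncertainty. Compound 3 is estimated at 3000 nM, with a range of 300 nM to 30000 nM. This estimate amounts to an expected step of an at least 3.3-fold lower number from compound 2 to compound 3 (0.52 log units; beyond the scatter), and a limit rather than a number is a real possibility.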

Compound 3, half-maximal effective concentration: 130 nM
Beside the measured number, compound 3's estimate is 23-fold (1.36 log units) above it; the measured number lies below the stated range.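

In this assay an alkoxy group on the acid chain is not in itself fatal to agonism: with ethoxy in place of hydrogen on the saturated chain carbon bound to the aromatic carbon, the step is only a 3.4-fold higher number from compound 1 to compound 3 (0.53 log units; beyond the scatter) and stays modest, whereas methoxy on the chain carbon bound to the carbonyl carbon gave an at least 260-fold higher number from compound 1 to compound 2 (2.42 log units; beyond the scatter) on the same core. Replacing 2-carboxy-2-methoxyethyl with 2-carboxy-1-ethoxyethyl restores a measurable response, with an at least 76-fold lower number from compound 2 to compound 3 (1.88 log units; beyond the scatter) on this read-out, so on these three compounds the outcome depends strongly on this combined change of alkoxy group and chain carbon. The value of compound 2 is a limit and not a number, so this step has a bound rather than a fixed size: the limit of > 10000 nM in this assay, at which 1 of the 3 values shown sits.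

From the compounds shown here alone, the placement and the lengthening from methoxy to ethoxy change together here, so their separate shares in the step remain open. Also open, going by these compounds, is how the chain carbon bound to the aromatic carbon responds to a hydroxyl group, an amine or a longer alkoxy group such as propoxy.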